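This account rests on a few compounds, and the source may have more. Where it says the series, first, only, none or still open, it means among the compounds named here.

Measured compounds:
- compound 1, `COc1cc(N(Cc2ccc(C)cc2)C(=O)CSc2nc3ccccc3s2)cc(OC)c1OC`, 54200 nM
- compound 2, `COc1ccc(CN(C(=O)CSc2nc3ccccc3s2)c2cc(OC)c(OC)c(OC)c2)cc1N=[N+]=[N-]`, 187 nM
- compound 3, `COc1ccc(CN(C(=O)CSc2nc3ccccc3s2)c2cc(OC)c(OC)c(OC)c2)cc1N`, 84 nM

These three compounds share one core and differ only in the group on a saturated chain carbon bound to an amide-type nitrogen. In a functional assay on MGC-803 cells (Homo sapiens) for antiproliferative activity, read by MTT assay, with a stated time of 48 h (on this read-out higher numbers stand for weaker inhibition and lower numbers for stronger inhibition), compound 2 stands second of the three measured numbers: compound 3 lies close to it, with a 2.2-fold lower number from compound 2 to compound 3 (0.35 log units; beyond the scatter), while compound 1 lies far away, with a 290-fold lower number from compound 1 to compound 2 (2.46 log units; beyond the scatter).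

Compound 4, `COc1cc(N(Cc2ccc(Br)cc2)C(=O)CSc2nc3ccccc3s2)cc(OC)c1OC`, has not yet been measured. It differs from compound 2 as follows: 4-bromophenyl in place of 3-azido-4-methoxyphenyl on a saturated chain carbon bound to an amide-type nitrogen. The 4-bromophenyl of compound 4 resembles the 4-methylphenyl of compound 1 more than the 3-azido-4-methoxyphenyl of compound 2, since both lack the azido and methoxy groups that the step of a 290-fold lower number from compound 1 to compound 2 (2.46 log units; beyond the scatter) showed to go with a much lower number. That step is the one that bears most directly on the change; the step of a 2.2-fold lower number from compound 2 to compound 3 (0.35 log units; beyond the scatter) is small by comparison and concerns only the azido itself. A large rise in the number, back toward compound 1, is therefore expected, though whether bromine and methyl behave alike is not known from these compounds.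

Compound 4 is estimated to give 25000 nM in this assay, within 4000 nM to 120000 nM, an expected step of a 130-fold higher number from compound 2 to compound 4 (2.13 log units; beyond the scatter).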

Compound 4, half-maximal inhibitory concentration: 48100 nM
For compound 4 the middle estimate is 1.9-fold (0.28 log units) below the measured one; low and high end bracket the measured number.
By their numbers in this assay, from the lowest: compound 3; then compound 2; then compounds 4 and 1 (each within the scatter of the next).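

In this assay, putting bromo in place of methyl on an aromatic carbon gives a 1.1-fold lower number from compound 1 to compound 4 (0.05 log units; within the scatter), so the 4-bromophenyl and 4-methylphenyl groups cannot be told apart at this position. The large gap to the substituted groups therefore no longer rests on 4-methylphenyl alone: it appears again as a 260-fold higher number from compound 2 to compound 4 (2.41 log units; beyond the scatter) and as a 570-fold higher number from compound 3 to compound 4 (2.76 log units; beyond the scatter), so among these four compounds, the two with 3-azido-4-methoxyphenyl or 3-amino-4-methoxyphenyl give low numbers and the two with a single group at position 4 of the ring give high numbers, with no compound going against this. Nothing measured here explains why these groups differ so widely.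

The methoxy always appears together with the azido or the amino, so these compounds cannot show which of them goes with the low numbers; a plain 4-methoxyphenyl or a 3-aminophenyl on the same carbon would pull the two apart. From the compounds shown here alone, it also remains open whether a hydroxy or a carboxylic acid in place of the amino would keep the number low.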